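Swapping a benzofuranyl amide for a sorbyl amide

This account rests on a few compounds, and the source may have more. Where it says the series, first, only, none or still open, it means among the compounds named here.

Compound 3 `CCCCCCCCCCCCCCCCCCNC(=O)[C@@H](NC(=O)c1cc2ccccc2o1)[C@@H](C)O` sits at the edge of the measured range: in a functional assay on SiHa cells (Homo sapiens) for cytotoxicity, read by MTT assay, with a stated time of 48 h (a higher number here means a weaker inhibitor, a lower number a stronger inhibitor), compound 3 gives only a limit, > 200000 nM. Compound 4 `C/C=C/C=C/C(=O)N[C@H](C(=O)NCCCCCCCCCCCCCCCCCC)[C@@H](C)O` differs from it in one place, (penta-1,3-dien-1-yl in place of 1-benzofuran-2-yl on a carbonyl carbon). Within the data shown here, one measured step bears on this position: an at least 5.0-fold higher number from compound 1 to compound 3 (0.70 log units; beyond the scatter), where compound 1 `CCCCCCCCCCCCCCCCCCNC(=O)[C@@H](N)[C@@H](C)O` gives 39500 nM. Among the measured compounds shown here, compound 2 `C/C=C/C=C/C(=O)N[C@H](C(=O)NCCCCCCCC)[C@@H](C)O`, which carries the same penta-1,3-dien-1-yl carbonyl but on an octyl chain, gives 123000 nM; no single-point step links it to compound 4. Both acylated compounds, compound 2 and compound 3, show higher numbers than compound 1, so the step of an at least 1.3-fold lower number from compound 3 to compound 4 (0.12 log units; that floor lies within the scatter) is expected to remain near the limit of > 200000 nM in this assay, at which 1 of the 3 values shown sits, or only modestly below it. Compound 4 is therefore estimated at 150000 nM, within 50000 nM to 400000 nM.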

Compound 4, half-maximal inhibitory concentration: > 200000 nM
Compound 4 gave a limit, no number (the forecaster's own chance of this, stated with the estimate: 35%); middle value at least 1.3-fold (0.12 log units) away from the limit.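

Compound 3 and compound 4 both give only a limit in this assay, so the step between them cannot be read: the limit of > 200000 nM in this assay, at which 2 of the 4 values shown sit.

Placing (penta-1,3-dien-1-yl)carbonyl on the amine nitrogen gives an at least 5.0-fold higher number from compound 1 to compound 4 (0.70 log units; beyond the scatter), so this acyl group, like (1-benzofuran-2-yl)carbonyl, raises the number beyond the scatter. Adding decyl to the chain gives an at least 1.6-fold higher number from compound 2 to compound 4 (0.21 log units; that floor lies within the scatter), and because that floor lies within the scatter, no firm chain effect can be read.

Going by these compounds, it remains open whether a simple acetyl group on this amine nitrogen would also raise the number, and how a dodecyl chain would compare.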